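This account rests on a few compounds, and the source may have more. Where it says the series, first, only, none or still open, it means among the compounds named here.

Measured so far in a functional assay on HepG2 cells (Homo sapiens) for cytotoxicity, read by MTT assay, with a stated time of 48 h; on this read-out lower numbers stand for stronger inhibition and higher numbers for weaker inhibition:
Compound 1 `Cc1ccccc1OCc1cn(-c2ccc(S(=O)(=O)N3CCc4ccccc4C3)cc2)nn1`: > 50 ug/mL
Compound 2 `Cc1ccc(OCc2cn(-c3ccc(S(=O)(=O)N4CCc5ccccc5C4)cc3)nn2)cc1`: > 50 ug/mL
Compound 3 `COc1cc2c(cc1OC)CN(S(=O)(=O)c1ccc(-n3cc(COc4ccc([N+](=O)[O-])cc4)nn3)cc1)CC2`: > 50 ug/mL

Every entry here is a limit and not a number: the limit of > 50 ug/mL in this assay, at which 3 of the 3 values shown sit. Compound 2 gives > 50 ug/mL, which is a limit, so it has no exact place among the three compounds.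

Compound 4 `O=S(=O)(c1ccc(-n2cc(CO)nn2)cc1)N1CCc2ccccc2C1` differs from compound 2 by hydrogen in place of 4-methylphenyl on an oxygen on a saturated carbon. In words, hydrogen stands in place of 4-methylphenyl on an oxygen on a saturated carbon, which turns 4-methylphenoxy into hydroxy.

Among the measured compounds shown here, the only measured step is a step that the two limits leave unreadable from compound 1 to compound 2, so it offers no size to carry over to this change. It also involves a different change. With compound 2 at > 50 ug/mL as the only anchor, no clear step is expected, and its direction cannot be told. The estimated step is a step that the limit leaves unreadable from compound 2 to compound 4. Compound 4 is expected to give 70 ug/mL, with an estimated range of 25 ug/mL to 200 ug/mL. The assay will most likely report only a limit again.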

Compound 4, half-maximal inhibitory concentration: > 50 ug/mL
Compound 4: a limit, no number (the forecaster's own chance of this, stated with the estimate: 75%); the middle value lies beyond the limit too.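

Compound 4 gives only a limit, as do compound 1 and compound 2, so no step between them can be read, and the same holds for compound 3: the limit of > 50 ug/mL in this assay, at which 4 of the 4 values shown sit.

The compounds shown leave open whether any of them truly differs from another in this assay, including whether hydrogen in place of 4-methylphenyl changes anything.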